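The compounds below may be only part of what the source reports. "The series", "measured", "known", "first", "only" and "open" are said of these compounds alone.

Measured compounds:
- compound 1 `COc1cc(C)cc(-c2c(-c3ccnc(-c4ccc(N(C)C)cc4)c3)cnn2CC#N)c1` gives 40%
- compound 2 `COc1cc(C)cc(-c2nn(CC#N)cc2-c2ccnc(-c3ccc(N(C)C)cc3)c2)c1` gives 61%

Both numbers come from a functional assay on Malme-3M cells (Homo sapiens) for cytotoxicity, read by sulforhodamine B assay, with a stated time of 48 h, tested at 1 uM; on this read-out higher numbers stand for a weaker effect at the one concentration tested and lower numbers for a stronger effect. For the measured compounds named here, compound 1 stands lowest of the two values known so far, which on this read-out means the stronger effect at the single concentration tested; compound 2 sits a margin higher that lies beyond the usual scatter. Going by the values given here, no single-point step between compound 1 and compound 2 is defined here, so nothing more than the two values themselves is taken from that pair.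

The next compound, compound 3 `COc1cc(C)cc(-c2c(-c3ccnc(-c4ccc(C(C)=O)cc4)c3)cnn2CC#N)c1`, is not yet measured. It is derived from compound 1 by one change: acetyl in place of dimethylamino on an aromatic carbon. Among the compounds with values here, no measured pair in this set makes that kind of change, so there is no step from which to read its size in this assay. A moderate shift to a weaker effect, that is to a higher number, is expected, without confidence that it will clear the scatter. For compound 3 the step of a number 12 percentage points higher from compound 1 to compound 3 (beyond the scatter) is the estimated outcome. Compound 3 is accordingly expected to give about 52% in this assay, with a plausible range from 28% to 76%.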

Compound 3, a percentage reported as activity, at one concentration (the size of the read-out at that concentration, not a potency): 36%
Compound 3: the middle estimate sits 16 percentage points above what was measured; low and high end bracket the measured number.
By their numbers in this assay, from the lowest: compounds 3 and 1 (each within the scatter of the next); then compound 2.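

In this assay, acetyl in place of dimethylamino on the aromatic carbon para to a large group gives a number 4 percentage points lower from compound 1 to compound 3 (within the scatter) and so no difference that can be read at the one concentration tested. For the compounds shown here, the earlier compounds had no step between them, and this is the first reading of a change at a single place: on the core of compound 1, the 4-(dimethylamino)phenyl group is not needed to hold the read-out, since the 4-acetylphenyl group stays within the scatter of it. No measurement bearing on a cause for this agreement is at hand.

On these data alone, with only these two groups at this position, the result cannot be extended to others, and it remains open how a carboxylic acid, a primary amine or a longer acyl chain such as butanoyl would read here. Also open, as far as these compounds go, is whether the same exchange on the core of compound 2 would read alike, and whether compound 1 and compound 3 would stay together at other concentrations.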